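Swapping the aryl group on the triazole-type nitrogen

This account rests on a few compounds, and the source may have more. Where it says the series, first, only, none or still open, it means among the compounds named here.

Compound 3, `COc1ccc([C@@H]2C/C(=N/OCc3cn(-c4ccc(NC(C)=O)cc4)nn3)c3cc(CC=C(C)C)c(OC)cc3O2)cc1`, gives 2% in a functional assay on PC-3 cells (Homo sapiens) for inhibition, read by sulforhodamine B assay, with a stated time of 48 h, tested at 50 uM; on this read-out lower numbers stand for less inhibition of growth and higher numbers for more inhibition of growth at the one concentration tested. That is the lowest of the three numbers shown. Compound 2, `C#CCO/N=C1/C[C@@H](c2ccc(OC)cc2)Oc2cc(OC)c(CC=C(C)C)cc21`, which carries only a short propargyl chain on the oxime oxygen, gives 41%, and compound 1, `COc1ccc([C@@H]2C/C(=N/OCc3cn(-c4ccccc4CO)nn3)c3cc(CC=C(C)C)c(OC)cc3O2)cc1`, gives 100%. Within the data shown here, the single step that has been measured at the aromatic nitrogen of the five-membered aromatic ring with 3 nitrogen is a number 98 percentage points lower from compound 1 to compound 3 (beyond the scatter), and it shows how strongly the read-out can move when one aryl group replaces another at that position.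

Compound 4, `COc1ccc([C@@H]2C/C(=N/OCc3cn(-c4cccnc4Cl)nn3)c3cc(CC=C(C)C)c(OC)cc3O2)cc1`, differs from compound 3 in one place: 2-chloropyridin-3-yl in place of 4-acetamidophenyl on an aromatic nitrogen. Among the measured compounds shown here, no measured step covers this particular exchange, so only the large swing between compound 1 and compound 3 speaks to it, and it says nothing about the direction for a 2-chloropyridin-3-yl group. Since compound 3 already sits at the bottom of the range, a move, if it comes, can hardly go lower, and the earlier step shows that an upward move could be large.

Compound 4 is therefore expected to show a number 43 percentage points higher from compound 3 to compound 4 (beyond the scatter), with the value estimated at 45% and a wide range from 5% to 95%.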

Compound 4, percent growth inhibition at one concentration: 44%
Estimate against measurement, compound 4: 1 percentage points above, and the stated range covers the measured number.
By their numbers in this assay, from the lowest: compound 3; then compounds 2 and 4 (each within the scatter of the next); then compound 1.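

In this assay, the aryl group on the aromatic nitrogen now has a second measured exchange, and this one runs upward: a number 42 percentage points higher from compound 3 to compound 4 (beyond the scatter). The 2-chloropyridin-3-yl group still falls well short of the 2-(hydroxymethyl)phenyl group, with a number 56 percentage points lower from compound 1 to compound 4 (beyond the scatter), so the three aryl groups at this one position give three clearly separated levels rather than a simple high and low. The comparison with the short chain adds a further point: a number 3 percentage points higher from compound 2 to compound 4 (within the scatter), so the 1-(2-chloropyridin-3-yl)-1H-1,2,3-triazol-4-yl group and the ethynyl group cannot be told apart here, while the same triazole carrying 4-acetamidophenyl or 2-(hydroxymethyl)phenyl gives numbers that lie clearly apart from that of compound 4.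

The compounds shown leave open which feature of the 2-(hydroxymethyl)phenyl group goes with the highest number, and a plain phenyl group or a 2-(aminomethyl)phenyl group at this position would be needed to address that. Nothing given here bears on why these aryl groups differ.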